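Swapping a Bulky Sulfone Chain for a Sulfonamide

The source may hold more compounds than are shown below. What is called first, only, known or untested is meant among the compounds shown, and "the series" means these compounds.

Compound 1 `Cn1c(-c2ccccc2C(F)(F)F)nnc1C12CCC(CCS(C)(=O)=O)(CC1)CC2`: in a functional assay on the whole organism (strain ICR) for inhibition, with Mus musculus as the target, with a stated time of 16 h, at a dose of 10 mg/kg by the oral route (a lower number here means less inhibition, a higher number more inhibition at the dose given (going by the name of the read-out)), compound 1 gives 63%
Compound 2 `Cn1c(-c2ccccc2C(F)(F)F)nnc1C12CCC(CCS(=O)(=O)C(C)(C)C)(CC1)CC2`: in this assay compound 2 gives 10%

Compound 2 stands lowest of the two numbers, with compound 1 the nearest, set apart by a number 53 percentage points lower from compound 1 to compound 2 (beyond the scatter). Compound 3 `Cn1c(-c2ccccc2C(F)(F)F)nnc1C12CCC(CNS(C)(=O)=O)(CC1)CC2` is not yet measured; it differs from compound 2 by methanesulfonamido in place of ((tert-butyl)sulfonyl)methyl on a saturated chain carbon bound to a saturated ring carbon. Only a number 53 percentage points lower from compound 1 to compound 2 (beyond the scatter) bears on this change: it likewise sets methyl against tert-butyl on a sulfonyl sulfur, in the opposite direction. Within the data shown here, the sulfonamide nitrogen and the shorter chain have no measured precedent. A rise beyond the scatter is therefore expected, a number 40 percentage points higher from compound 2 to compound 3 (beyond the scatter), with added uncertainty. Compound 3 is estimated at 50%, between 20% and 78%.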

Compound 3, a percentage reported as inhibition, in the whole organism at one dose (the size of the read-out at that dose, not a potency): 27%
Beside the measured number, compound 3's estimate is 23 percentage points above it; low and high end bracket the measured number.
By their numbers in this assay, from the lowest: compound 2; then compound 3; then compound 1.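

In this assay, methanesulfonamido gives a number 17 percentage points higher from compound 2 to compound 3 (beyond the scatter) but also a number 36 percentage points lower from compound 1 to compound 3 (beyond the scatter) in place of the methylsulfonyl-bearing chain. A methyl on the sulfonyl sulfur therefore does not by itself restore the level of compound 1, since compound 3 carries that methyl too. No measured property is available to explain either step. The change also swaps the chain and brings in a nitrogen at once, so these two parts cannot be told apart. As far as these compounds go, a 2-(methanesulfonamido)ethyl group in the same place would separate them, and how it would read out remains open.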